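This account rests on a few compounds, and the source may have more. Where it says the series, first, only, none or still open, it means among the compounds named here.

The measured compounds in an assay on CHO cells for displacement of a labelled ligand from melatonin receptor type 1B (Homo sapiens), read by scintillation counting, with a stated time of 60 min (a lower number here means a stronger inhibitor, a higher number a weaker inhibitor), are these:

compound 1 `COc1ccc(O)c(CCCNC(C)=O)c1` gives 46.2 nM
compound 2 `CCCOc1ccc(OC)cc1CCCNC(C)=O` gives 2.12 nM
compound 3 `COc1ccc(OCCc2ccccc2)c(CCCNC(C)=O)c1` gives 13.4 nM

Compound 3 stands second highest of the three numbers in this assay. The nearer of its two steps is a 3.4-fold lower number from compound 1 to compound 3 (0.54 log units; beyond the scatter); the further is a 6.3-fold higher number from compound 2 to compound 3 (0.80 log units; beyond the scatter). All three compounds share a core that carries the acetamide chain, and they differ only in what sits on the ring oxygen.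

Compound 4 `COc1ccc(OCCCc2ccccc2)c(CCCNC(C)=O)c1` is the next member of the series. The change from compound 3 is benzyl in place of phenyl on a saturated chain carbon, two bonds along the chain from an oxygen on an aromatic ring. Of the measured steps, the one at the same place is a 6.3-fold higher number from compound 2 to compound 3 (0.80 log units; beyond the scatter), which lengthened the chain end and raised the number. The two steps from the free hydroxyl, a 22-fold lower number from compound 1 to compound 2 (1.34 log units; beyond the scatter) and a 3.4-fold lower number from compound 1 to compound 3 (0.54 log units; beyond the scatter), both lowered the number, the shorter substituent by more. For the measured compounds named here, no measured step goes from phenyl to benzyl at this carbon, so the direction is not fixed by the data. The expected step in this assay is a 1.2-fold lower number from compound 3 to compound 4 (0.09 log units; within the scatter), small and within the scatter, with the chance of either direction. Compound 4 is therefore estimated at 11 nM, within a range of 3.5 nM to 35 nM.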

Compound 4, inhibition constant: 72.2 nM
Beside the measured number, compound 4's estimate is 6.6-fold (0.82 log units) below it; measured number outside the range, above it.
By their numbers in this assay, from the lowest: compound 2; then compound 3; then compounds 1 and 4 (each within the scatter of the next).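

In this assay the result shows that the upward trend at this carbon does not stop at compound 3: a 5.4-fold higher number from compound 3 to compound 4 (0.73 log units; beyond the scatter) is a second modest rise in the number, close in size to a 6.3-fold higher number from compound 2 to compound 3 (0.80 log units; beyond the scatter) at the same place. Across compound 2, compound 3 and compound 4, the number therefore goes up at each step as the group on the ring oxygen grows from propyl through phenethyl to the chain ending in benzyl, and the whole distance is large, with a 34-fold higher number from compound 2 to compound 4 (1.53 log units; beyond the scatter) as the combined step. Compound 4 also stands within the scatter of the free hydroxyl of compound 1, so the lowering seen on capping that oxygen with propyl or phenethyl does not appear with this longer group.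

The compounds shown leave open whether a still longer chain ending in phenyl would raise the number further, and what an amine or a carboxylic acid at the chain end would do. Nothing available here bears on why the number rises along this series.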